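A few compounds are considered here, and "the series" means these few. Any claim that something is new, unique, unknown or untested is made for them only; others in the source may bear on it.

- compound 1 `CCCCCCCCCCCCCC(=O)Nc1nnc(S[C@@H]2O[C@H](COC(C)=O)[C@H](OC(C)=O)[C@H](OC(C)=O)[C@H]2OC(C)=O)s1`: 16300 nM
- compound 2 `CCCCCCCC/C=C\CCCCCCCC(=O)Nc1nnc(S[C@@H]2O[C@H](COC(C)=O)[C@H](OC(C)=O)[C@H](OC(C)=O)[C@H]2OC(C)=O)s1`: 26300 nM
- compound 3 `CCCCCCCCCC(=O)Nc1nnc(S[C@@H]2O[C@H](CO)[C@H](O)[C@H](O)[C@H]2O)s1`: "not active" (no number reported)

Within the data shown here, in an ADME assay on CHO-K1 cells (Cricetulus griseus) for cytotoxicity, read by MTT assay, with a stated time of 24 h (on this read-out lower numbers stand for stronger inhibition and higher numbers for weaker inhibition), compound 3 has no number and is reported only as "not active" (no number reported), so no step can be counted from it. Compound 4 `CCCCCCCCCCCCCCCC(=O)Nc1nnc(S[C@@H]2O[C@H](CO)[C@H](O)[C@H](O)[C@H]2O)s1` differs from compound 3 in its chain: hexyl in place of hydrogen on a saturated chain carbon, nine bonds along the chain from a carbonyl carbon. Among the measured compounds shown here, the one measured step that bears on this, a 1.6-fold higher number from compound 1 to compound 2 (0.21 log units; within the scatter), is also a chain change, though on the core of compound 1, and it stays within the scatter. Chain length alone is therefore not expected to bring a clear shift, so compound 4 should stay weak in this assay and may also be reported without a number. For compound 4 the expected value is 40000 nM, with an estimated range of 12000 nM to 130000 nM.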

Compound 4, half-maximal inhibitory concentration: "not active" (no number reported)
Compound 4 has no reported number here; no gap can be computed for the estimate.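

In this assay compound 3 and compound 4 are both reported only as "not active", so no step can be read between them. What the hexyl difference does to this read-out stays open, and nothing measured here offers an explanation.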